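Notes on the step from compound 1 to compound 4

A few compounds are considered here, and "the series" means these few. Any claim that something is new, unique, unknown or untested is made for them only; others in the source may bear on it.

Measured so far in a functional assay (muscle tissue) with Cavia porcellus as the target (on this read-out higher numbers stand for an effect only at larger amounts of compound and lower numbers for an effect already at smaller amounts), on three compounds
- compound 1 `COC(=O)C1=C(C)N=C(C)/C(=C(\O)OC)C1c1cc(Cl)cc(Cl)c1` gives 93.3 nM
- compound 2 `COC(=O)C1=C(C)NC(C)=C(C(=O)OC)C1c1ccccc1` gives 28.2 nM
- compound 3 `COC(=O)C1=C(C)N=C(C)/C(=C(\O)OC)C1c1cc(OC)c(OC)cc1OC` gives 1000000 nM

Compound 1 stands second highest of the three numbers in this assay, with compound 2 lower and compound 3 far higher. Both gaps lie beyond the usual scatter. The next compound to be read is compound 4 `COC(=O)C1=C(C)N=C(C)/C(=C(\O)OC)C1c1ccc(F)cc1`, which is not yet measured. It carries 4-fluorophenyl in place of 3,5-dichlorophenyl on a saturated ring carbon and leaves the rest of the core of compound 1 unchanged.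

Among the compounds with values here, no two measured compounds differ in one place only, so the series offers no direct precedent for the size of this step. The values show only how wide the series runs, from compound 2 at 28.2 nM to compound 3 at 1000000 nM in the same read-out. A moderate move toward a higher number is expected, beyond the scatter but far short of the gap to compound 3. The expected step is a 3.2-fold higher number from compound 1 to compound 4 (0.51 log units; beyond the scatter) in this assay, and this estimate is uncertain. Compound 4 is estimated at 300 nM, within an expected range of 50 nM to 2500 nM for the measurement.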

Compound 4, half-maximal effective concentration: 129 nM
For compound 4 the middle estimate is 2.3-fold (0.37 log units) above the measured one, and the stated range covers the measured number.
By their numbers in this assay, from the lowest: compound 2; then compounds 1 and 4 (each within the scatter of the next); then compound 3.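

In this assay, within the data shown here, the exchange of 3,5-dichlorophenyl for 4-fluorophenyl on the saturated ring carbon gives a 1.4-fold higher number from compound 1 to compound 4 (0.14 log units; within the scatter) and this is the first step that changes one place only. It shows that, with the rest of the core of compound 1 held constant, this read-out does not separate these two halogen-bearing phenyl groups, even though chlorine gives way to fluorine and the number of halogen atoms and their places on the phenyl ring change together. No measurement bears on why the two groups read alike, and this single step cannot divide the result among those simultaneous changes.

Open, from the compounds shown here alone, is how far this tolerance extends at the saturated ring carbon, for example to a phenyl group carrying an amine or a carboxylic acid, or to a longer alkyl chain in place of the aromatic ring. Also open, going by these compounds, is whether a phenyl group carrying only one chlorine, or fluorine at another ring place, would read alike in this assay and so separate the effect of the halogen from that of its place.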